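Swapping One Aromatic Group on a Shared Core

The source may hold more compounds than are shown below. What is called first, only, known or untested is meant among the compounds shown, and "the series" means these compounds.

In a functional assay on A549 cells (Homo sapiens) for inhibition, read by MTT assay, with a stated time of 48 h (a higher number here means a weaker inhibitor, a lower number a stronger inhibitor), compound 1 `Cc1ccc(NC(=O)Nc2cccc(-c3cccc4[nH]nc(N)c34)c2)cc1` gives 1660 nM and compound 2 `Cc1ccc(NC(=O)Nc2cccc(-c3cccc4[nH]nc(N)c34)c2)cc1Cl` gives 1750 nM. Within the data shown here, these two numbers lie within the scatter of each other, so compound 2 stands level with the only other measured compound. Compound 3 `Nc1n[nH]c2cccc(-c3cccc(NC(=O)Nc4cccc(F)c4)c3)c12` keeps the shared core but carries 3-fluorophenyl in place of 3-chloro-4-methylphenyl on an amide-type nitrogen. Among the measured compounds shown here, one measured step bears on this change: putting chloro in place of hydrogen on an aromatic carbon gave a 1.1-fold higher number from compound 1 to compound 2 (0.02 log units; within the scatter), which is within the scatter. For the measured compounds named here, no measured compound here carries fluoro, so this guidance is thin and points to no direction. The expected change in this assay is therefore no larger than the scatter, and the estimate is a 1.0-fold higher number from compound 2 to compound 3 (0.01 log units; within the scatter). For compound 3 the estimated value is 1800 nM, with an expected range of 700 nM to 4500 nM.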

Compound 3, half-maximal inhibitory concentration: 1360 nM
Compound 3: the middle estimate sits 1.3-fold (0.12 log units) above what was measured, within the range that was stated.
By their numbers in this assay, from the lowest: compounds 3, 1 and 2 (each within the scatter of the next).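

Replacing the whole aromatic group on the amide-type nitrogen, rather than adding a single chloro, still produces no readable change in this assay: 3-fluorophenyl in place of 3-chloro-4-methylphenyl gives a 1.3-fold lower number from compound 2 to compound 3 (0.11 log units; within the scatter), and 3-fluorophenyl in place of 4-methylphenyl gives a 1.2-fold lower number from compound 1 to compound 3 (0.09 log units; within the scatter). Both steps lie within the scatter, so compound 1, compound 2 and compound 3 cannot be told apart, and this position accepts these three substituted phenyl groups with no measurable difference. No supporting measurement is available to explain why these groups read alike.

The compounds shown leave open whether this nitrogen would give a similar number with no aromatic group at all, for example with a plain alkyl chain or a chain ending in an amine. They also leave open whether a carboxylic acid on the phenyl group would shift the number beyond the scatter.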